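Swapping the Oxygen-Bearing Ring of Compound 3 for Cyclohexyl

A few compounds are considered here, and "the series" means these few. Any claim that something is new, unique, unknown or untested is made for them only; others in the source may bear on it.

Measured compounds:
compound 1, `COc1ccc(-c2nc(SCC3C[C@](C)(O)CC(=O)O3)[nH]c2-c2ccc(OC)cc2)cc1`, 420 nM
compound 2, `CO[C@]1(C)C[C@H](O)C[C@@H](CSc2nc(-c3ccccc3)c(-c3ccccc3)[nH]2)O1`, 30 nM
compound 3, `O=C1CCCC(CSc2nc(-c3ccccc3)c(-c3ccccc3)[nH]2)O1`, 740 nM

Of the compounds shown here, three sharing a thioether-linked core have been measured in an assay on microsomes from liver for inhibition of sterol O-acyltransferase 1 (Rattus norvegicus); on this read-out lower numbers stand for stronger inhibition and higher numbers for weaker inhibition. Compound 3, `O=C1CCCC(CSc2nc(-c3ccccc3)c(-c3ccccc3)[nH]2)O1`, gives 740 nM, the highest of the three numbers. Its nearest neighbour is compound 1, which gives 420 nM; this gap lies within the scatter of the assay, so no order between the two can be claimed. Compound 2 gives 30 nM, a gap from compound 3 that lies well beyond the scatter.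

The step to be followed leads from compound 3 to compound 4, `c1ccc(-c2nc(SCC3CCCCC3)[nH]c2-c2ccccc2)cc1`. The change is a group of 6 heavy atoms (6 carbon; one six-membered non-aromatic ring of carbon only) in place of a group of 7 heavy atoms (5 carbon, 2 oxygen; one six-membered non-aromatic ring with 1 hetero atom), on a saturated chain carbon bound to a sulfur. Among the measured compounds shown here, no measured pair in this set shows this particular exchange, so the size of the step has to be judged from the structural change alone, without a direct precedent. The two oxygens of the leaving group, one of which sits in a double bond outside aromatic rings, are lost and nothing with a hydrogen-bond acceptor takes their place.

The step of a 1.2-fold higher number from compound 3 to compound 4 (0.09 log units; within the scatter) is expected to be modest, and is as likely to lie within the scatter as beyond it. For compound 4 the estimate in this assay is 900 nM, with a range from 200 nM to 4000 nM.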

Compound 4, half-maximal inhibitory concentration: 100 nM
Estimate against measurement, compound 4: 9.0-fold (0.95 log units) above; measured number outside the range, below it.
By their numbers in this assay, from the lowest: compound 2; then compound 4; then compounds 1 and 3 (each within the scatter of the next).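

In this assay, among the compounds shown here, the exchange of the oxygen-bearing ring for cyclohexyl on a saturated chain carbon bound to a sulfur gives a 7.4-fold lower number from compound 3 to compound 4 (0.87 log units; beyond the scatter), so a ring of carbon only, with no hydrogen-bond acceptors, is tolerated at this place and outperforms the lactone-type ring of compound 3, something the earlier compounds, all with oxygen-bearing rings here, could not show. The oxygens are nevertheless not a liability as such: compound 2 keeps an oxygen-bearing ring and gives 30 nM, a lower number than compound 4 at 100 nM, so what sits at this place matters by more than the presence or absence of oxygen. Nothing available explains why the number falls with this exchange.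

The compounds shown leave open whether a hydroxyl or an amine on the cyclohexyl ring, or an open hexyl chain in its place, would lower the number further or raise it. They also do not tell whether cyclohexyl would give a similar step on the core of compound 1, with its two methoxy groups.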